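The compounds below may be only part of what the source reports. "The series", "measured", "known", "first", "only" and "open" are said of these compounds alone.

In a functional assay on A549 cells (Homo sapiens) for cytotoxicity, read by MTT assay, with a stated time of 72 h (a higher number here means a weaker inhibitor, a lower number a stronger inhibitor), compound 1 `O=S(=O)(c1ccccc1)c1nc2ccccc2nc1Nc1ccccc1` gives 26300 nM and compound 3 `Cc1ccc(S(=O)(=O)c2nc3ccccc3nc2Nc2ccccc2)cc1` gives 12500 nM, the lower of these two actual numbers. For compound 2 `O=S(=O)(c1ccccc1)c1nc2ccccc2nc1Nc1ccc(F)cc1` the reading is only a limit, > 50000 nM.

Compound 4 `Cc1ccc(S(=O)(=O)c2nc3ccccc3nc2Nc2ccc(N)cc2)cc1` differs from compound 3 by amino in place of hydrogen on an aromatic carbon, para to a large group. Two measured replacements of hydrogen bear on this change. Fluoro gave an at least 1.9-fold higher number from compound 1 to compound 2 (0.27 log units; that floor lies within the scatter), and methyl gave a 2.1-fold lower number from compound 1 to compound 3 (0.32 log units; beyond the scatter). Neither replacement is amino, so the data set no firm direction, and only a small step is expected. The estimated change is a 1.3-fold lower number from compound 3 to compound 4 (0.10 log units; within the scatter). For compound 4 the expected value is 10000 nM, with an estimated range from 3000 nM to 35000 nM.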

Compound 4, half-maximal inhibitory concentration: 24600 nM
Compound 4: middle estimate off by 2.5-fold (0.39 log units), on the low side; measured number inside the range.
By their numbers in this assay, from the lowest: compounds 3, 4 and 1 (each within the scatter of the next, the first and the last beyond it). At a limit, above all of these: compound 2.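

Putting amino on the anilino group of compound 3 gives a 2.0-fold higher number from compound 3 to compound 4 (0.29 log units; within the scatter), so this change cannot be told apart from the ordinary spread of repeat measurements. Until now, the only group shown at this position was fluoro, and compound 2 gives a limit rather than an actual number: the limit of > 50000 nM in this assay, at which 1 of the 4 values shown sits. Compound 4 therefore provides the first actual number for a group at this position.

Going by these compounds, whether a carboxylic acid, a methoxy group or a longer chain here would shift the number beyond the scatter remains open. So does whether amino would behave the same way in compound 1, which lacks the methyl.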